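Swapping a Cyanophenyl for a Saturated Oxygen Ring

The compounds below may be only part of what the source reports. "The series", "measured", "known", "first", "only" and "open" are said of these compounds alone.

For the measured compounds named here, in an assay on HEK293 cells for agonist activity at Bile acid receptor (Homo sapiens), read by a luciferase reporter (on this read-out higher numbers stand for an effect only at larger amounts of compound and lower numbers for an effect already at smaller amounts), compound 2 `CC(C)OC(=O)C1CN(C(=O)c2ccc(C#N)cc2)CC(C)(C)c2cc(C#N)[nH]c21` gives 5700 nM, the highest of the three numbers measured so far. Going by the values given here, compound 1 `CC(C)OC(=O)C1CN(C(=O)c2cccc(Cl)c2)CC(C)(C)c2cc(C#N)[nH]c21` gives 1300 nM, and the only single-change step among the measured compounds is a 4.4-fold higher number from compound 1 to compound 2 (0.64 log units; beyond the scatter). Compound 3 `CC(C)OC(=O)C1=CN(C(=O)C2CCCCC2)CC(C)(C)c2cc(C#N)[nH]c21` gives 6.5 nM; it carries a saturated ring on the same carbonyl but also differs in its core, so its wide gap from compound 2 cannot be tied to one change. Compound 4 `CC(C)OC(=O)C1CN(C(=O)C2CCOCC2)CC(C)(C)c2cc(C#N)[nH]c21` differs from compound 2 by oxan-4-yl in place of 4-cyanophenyl on a carbonyl carbon. Among the compounds with values here, no measured step isolates an aromatic ring giving way to a saturated one, so the expectation is loose, leaning toward a lower number because compound 3 reaches 6.5 nM. Compound 4 is estimated at 400 nM, in the range 40 nM to 4000 nM. The expected step is a 14-fold lower number from compound 2 to compound 4 (1.15 log units; beyond the scatter).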

Compound 4, half-maximal effective concentration: 3300 nM
The estimate for compound 4 lay 8.3-fold (0.92 log units) below the measured number, and the stated range covers the measured number.
By their numbers in this assay, from the lowest: compound 3; then compound 1; then compounds 4 and 2 (each within the scatter of the next).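

In this assay, on this carbonyl carbon, oxan-4-yl in place of 4-cyanophenyl gives a 1.7-fold lower number from compound 2 to compound 4 (0.24 log units; within the scatter), so this saturated oxygen ring and that aromatic ring cannot be told apart here. Oxan-4-yl in place of 3-chlorophenyl gives a 2.5-fold higher number from compound 1 to compound 4 (0.40 log units; beyond the scatter), a modest step. Among these three compounds, giving up the aromatic ring at this position therefore brings no lower number.

As far as these compounds go, how an amine-bearing ring such as piperidin-4-yl, or a longer carbon chain, would read at this carbonyl remains open. Nothing available explains these steps.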